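A few compounds are considered here, and "the series" means these few. Any claim that something is new, unique, unknown or untested is made for them only; others in the source may bear on it.

Measured in a functional assay on RS4-11 cells (Homo sapiens) for inhibition, read by CCK-8 assay, with a stated time of 48 h, tested at 20 uM; a lower number here means less inhibition of growth, a higher number more inhibition of growth at the concentration tested:
- compound 1 `Cc1ccc(S(=O)(=O)Oc2ccccc2/C=C(\C#N)C(=O)Nc2nnc(Cc3cccc4ccccc34)s2)cc1`: 73%
- compound 2 `N#C/C(=C\c1ccccc1OS(=O)(=O)c1ccc(Cl)cc1)C(=O)Nc1nnc(Cc2ccccc2)s1`: 73%
- compound 3 `Cc1ccc(S(=O)(=O)Oc2ccccc2/C=C(\C#N)C(=O)Nc2nnc(Cc3ccc(F)cc3)s2)cc1`: 72%

All three values lie within the scatter of one another, so compound 3 stands level with the others. Compound 4 `N#C/C(=C\c1ccccc1OS(=O)(=O)c1ccc(Cl)cc1)C(=O)Nc1nnc(Cc2ccc(F)cc2)s1` differs from compound 3 as follows: chloro in place of methyl on an aromatic carbon. Within the data shown here, no measured step covers this exchange. The only one, a number 1 percentage points lower from compound 1 to compound 3 (within the scatter), lies elsewhere in the molecule. Compound 2, which also carries (4-chlorophenyl)sulfonyl, gives 73%. No step beyond the scatter is therefore expected in this assay. The expected change is a number 1 percentage points higher from compound 3 to compound 4 (within the scatter). For compound 4 the estimate is 73%, with an expected range of 63% to 82%.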

Compound 4, percent growth inhibition at one concentration: 68%
Estimate against measurement, compound 4: 5 percentage points above; low and high end bracket the measured number.
By their numbers in this assay, from the lowest: compounds 4, 3, 1 and 2 (each within the scatter of the next).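

In this assay, among these compounds, (4-chlorophenyl)sulfonyl in place of (4-methylphenyl)sulfonyl gives a number 4 percentage points lower from compound 3 to compound 4 (within the scatter) and is the first exchange read at this position, where chloro and methyl stand level. With chloro held, fluoro in place of hydrogen on an aromatic carbon gives a number 5 percentage points lower from compound 2 to compound 4 (within the scatter) and so also leaves the growth inhibition level. Nothing available explains why these exchanges leave the read-out unchanged.

From the compounds shown here alone, whether an amine or a carboxylic acid at this position would move the read-out beyond the scatter remains open. Also open, going by these compounds, is whether these level values would separate at other concentrations.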